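This account rests on a few compounds, and the source may have more. Where it says the series, first, only, none or still open, it means among the compounds named here.

Two compounds share one core that carries two long fatty acid chains, a thioether and an amide. Compound 1 `CCCCCCCCCCCC(=O)OC[C@H](CSC[C@@H](N)C(=O)NCCCS(=O)(=O)O)OC(=O)CCCCCCCCCCC` bears a 3-sulfopropyl group on its amide nitrogen, and in an assay on HEK293 cells for agonist activity at Toll-like receptor 2 (Homo sapiens) (a higher number here means that more compound is needed for the effect, a lower number that less compound is needed), compound 1 gives 5560 nM. Compound 2 `CCCCCCCCCCCC(=O)OC[C@H](CSC[C@@H](N)C(=O)NC(C)CCc1ccccc1)OC(=O)CCCCCCCCCCC` carries a 1-methyl-3-phenylpropyl group there instead, and in this assay compound 2 gives 160 nM. Among the measured compounds shown here, the only step so far, a 35-fold lower number from compound 1 to compound 2 (1.54 log units; beyond the scatter), shows how strongly the group on the amide nitrogen can move the result. For the measured compounds named here, compound 2 therefore stands at the lowest of the two numbers, with compound 1 as its only neighbour.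

Compound 3 `CCCCCCCCCCCC(=O)OC[C@H](CSC[C@@H](N)C(=O)NC(C)c1ccc(O)cc1)OC(=O)CCCCCCCCCCC` alters the same region once more: 4-hydroxyphenyl in place of phenethyl on a saturated chain carbon bound to an amide-type nitrogen and a saturated chain carbon. Going by the values given here, no measured step tests this particular swap directly. Among the compounds with values here, the only guide, a 35-fold lower number from compound 1 to compound 2 (1.54 log units; beyond the scatter), was a change of the whole nitrogen substituent, whereas here an aromatic ring is kept and only its distance from the chain and a hydroxyl group differ, so a smaller move is expected, most likely toward a higher number, a 2.5-fold higher number from compound 2 to compound 3 (0.40 log units; beyond the scatter). For compound 3 in this assay the estimate is 400 nM, with a range from 100 nM to 2000 nM.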

Compound 3, half-maximal effective concentration: 2890 nM
The estimate for compound 3 lay 7.2-fold (0.86 log units) below the measured number; the measured number lies above the stated range.
By their numbers in this assay, from the lowest: compound 2; then compounds 3 and 1 (each within the scatter of the next).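

In this assay, keeping an aromatic ring on this nitrogen substituent does not by itself preserve the low number, as the large step shows: an 18-fold higher number from compound 2 to compound 3 (1.26 log units; beyond the scatter). The 1-(4-hydroxyphenyl)ethyl group also gives no clear gain over the 3-sulfopropyl group, since a 1.9-fold lower number from compound 1 to compound 3 (0.28 log units; within the scatter) lies within the usual scatter, so compound 3 and compound 1 cannot be told apart here even though only compound 3 carries an aromatic ring in that place. Among these compounds, then, the low number belongs to compound 2 alone, and nothing available here explains why its 1-methyl-3-phenylpropyl group differs so much from the 1-(4-hydroxyphenyl)ethyl group of compound 3.

Two things change together from compound 2 to compound 3, the chain that links the ring and the hydroxyl group on the ring, so the compounds shown leave open which of them accounts for the step. A 1-phenylethyl group, which has the short link without the hydroxyl, and a 1-methyl-3-(4-hydroxyphenyl)propyl group, which has the hydroxyl with the longer link, would separate the two.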